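The compounds below may be only part of what the source reports. "The series", "measured", "known", "first", "only" and "open" are said of these compounds alone.

Compound 2 `Brc1cc(N2CC[C@H]3CN[C@H]3C2)cnc1Br` gives 7.8 nM in a functional assay on HEK293 cells for agonist activity at Neuronal acetylcholine receptor; alpha4/beta2 (Homo sapiens), read by FLIPR (a higher number here means that more compound is needed for the effect, a lower number that less compound is needed), the lowest of the two numbers recorded; the other compound, compound 1 `Brc1cncc(N2CC[C@@H]3CN[C@@H]3C2)c1`, gives 1000 nM in this assay, a gap beyond the scatter. Compound 3 `Brc1cc(N2CC[C@@H]3CN[C@@H]3C2)cnc1Br` is the mirror image of compound 2: the two compounds have the same atoms and bonds and differ only in configuration as drawn: 2 of 2 stereo elements differ (all stereocentres are inverted: mirror images); a stereocentre at a saturated ring carbon is drawn S in compound 2 and R in compound 3; a stereocentre at a saturated ring carbon is drawn R in compound 2 and S in compound 3. Within the data shown here, no step between two measured compounds tells how an inversion of both stereocentres plays out here, so the expectation rests on compound 2 alone. A step of some size toward a higher number is expected, a 19-fold higher number from compound 2 to compound 3 (1.28 log units; beyond the scatter), and compound 3 is estimated at 150 nM, within 30 nM to 1000 nM.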

Compound 3, half-maximal effective concentration: 76 nM
Compound 3: middle estimate off by 2.0-fold (0.30 log units), on the high side; low and high end bracket the measured number.
By their numbers in this assay, from the lowest: compound 2; then compound 3; then compound 1.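

In this assay the mirror images are separated by a 9.7-fold higher number from compound 2 to compound 3 (0.99 log units; beyond the scatter), and this gap can be traced to configuration alone because of one fact: the fact that compounds 2 and 3 differ only in the configuration as drawn. With the configuration held fixed, bromo in place of hydrogen on an aromatic carbon gives a 13-fold lower number from compound 1 to compound 3 (1.12 log units; beyond the scatter). The earlier pair differed in both the bromo and the configuration, so it could not separate these two changes.

On these data alone, whether the inversion has the same size without the added bromo remains open. So does whether chloro or methoxy in its place would lower the number as far.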